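The compounds below may be only part of what the source reports. "The series", "measured", "known", "first", "only" and "open" are said of these compounds alone.

Measured compounds:
compound 1, `CCCc1ccc(NC(=O)N[C@@H](C)c2ccccc2)cc1`, 76%
compound 2, `C[C@H](NC(=O)Nc1ccc(C(F)(F)F)cc1)c1ccccc1`, 94%

Within the data shown here, in an ADME assay on the whole organism with Oryza sativa as the target, tested at 1 uM (on this read-out higher numbers stand for a weaker effect at the one concentration tested and lower numbers for a stronger effect), compound 2 gives 94%, the highest of the two numbers; the nearest is compound 1, which in this assay gives 76%, and the change a number 18 percentage points higher from compound 1 to compound 2 (beyond the scatter) is the only measured step. Compound 3, `CCOC(=O)c1ccc(NC(=O)N[C@@H](C)c2ccccc2)cc1`, has not yet been measured. It differs from compound 2 by ethoxycarbonyl in place of trifluoromethyl on an aromatic carbon. Among the measured compounds shown here, the single measured step, trifluoromethyl in place of propyl, concerns the same position but a different pair of groups, so it bears on this change only loosely: it shows that the group at this aromatic carbon can move the read-out by a modest amount, without pointing to a direction for ethoxycarbonyl. With nothing closer to go on, the expected change a number 9 percentage points lower from compound 2 to compound 3 (within the scatter) is none beyond the scatter, with a wide range to allow for a modest move either way. For compound 3 in this assay the estimate is 85%, with a range from 65% to 100%.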

Compound 3, a percentage reported as activity, at one concentration (the size of the read-out at that concentration, not a potency): 97%
For compound 3 the middle estimate is 12 percentage points below the measured one, within the range that was stated.
By their numbers in this assay, from the lowest: compound 1; then compounds 2 and 3 (each within the scatter of the next).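

At the aromatic carbon para to a large group, replacing trifluoromethyl with ethoxycarbonyl gives, in this assay, a number 3 percentage points higher from compound 2 to compound 3 (within the scatter), so this larger group, which unlike trifluoromethyl carries hydrogen-bond acceptors, cannot be told apart from trifluoromethyl on this read-out. Replacing propyl with ethoxycarbonyl gives a number 21 percentage points higher from compound 1 to compound 3 (beyond the scatter), a second step beyond the scatter that starts from compound 1, which now stands apart from both compound 2 and compound 3 as the compound with the strongest effect at the one concentration tested. Among these three compounds, the separation is therefore between propyl on one side and trifluoromethyl and ethoxycarbonyl on the other, but no measurement available here explains that separation.

These compounds leave open whether propyl is unusual or whether other carbon chains, such as ethyl or a longer chain, would give similarly low numbers in this assay. They also leave open where an amine, a carboxylic acid or a methoxy group at this carbon would fall, and whether the same separation would hold with any other change to the shared core.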